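Aryl variation at the amine-bound chain carbon

The source may hold more compounds than are shown below. What is called first, only, known or untested is meant among the compounds shown, and "the series" means these compounds.

Going by the values given here, compound 3 `O=S(=O)(NCCCNCc1ccc(C(F)(F)F)cc1)c1cc(C(F)(F)F)cc(C(F)(F)F)c1` gives the lowest number of the three measured so far in a functional assay on A2780 cells (Homo sapiens) for inhibition, read by MTT assay, with a stated time of 72 h (a lower number here means a stronger inhibitor of growth, a higher number a weaker inhibitor of growth), 2800 nM. Compound 2 `COc1ccc(CNCCCNS(=O)(=O)c2cc(C(F)(F)F)cc(C(F)(F)F)c2)cc1OC` sits nearest, 3800 nM, with a 1.4-fold lower number from compound 2 to compound 3 (0.13 log units; within the scatter), so the two are not separated; compound 1 `O=S(=O)(NCCCNCc1ccccc1Cl)c1cc(C(F)(F)F)cc(C(F)(F)F)c1` is furthest, 9300 nM, with a 3.3-fold lower number from compound 1 to compound 3 (0.52 log units; beyond the scatter). Compound 4 `O=S(=O)(NCCCNCc1cccc2ccccc12)c1cc(C(F)(F)F)cc(C(F)(F)F)c1` carries naphthalen-1-yl in place of 4-(trifluoromethyl)phenyl on a saturated chain carbon bound to an amine nitrogen. Among the compounds with values here, no measured step exchanges one aryl group for another lacking heteroatoms; the steps of a 2.4-fold lower number from compound 1 to compound 2 (0.39 log units; beyond the scatter) and a 3.3-fold lower number from compound 1 to compound 3 (0.52 log units; beyond the scatter) show that the aryl group at this place moves the number only modestly, and a 1.4-fold lower number from compound 2 to compound 3 (0.13 log units; within the scatter) shows two different aryl groups giving near-identical numbers. Compound 4 is therefore expected close to compound 3, with a 1.1-fold higher number from compound 3 to compound 4 (0.03 log units; within the scatter). The estimate for compound 4 in this assay is 3000 nM, ranging from 1200 nM to 7500 nM.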

Compound 4, concentration for 50% growth inhibition: 3100 nM
Estimate against measurement, compound 4: 1.0-fold (0.01 log units) below; the measured number falls inside the stated range.
By their numbers in this assay, from the lowest: compounds 3, 4 and 2 (each within the scatter of the next); then compound 1.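

In this assay naphthalen-1-yl, with 2 six-membered aromatic rings of carbon only and no fluorine, is not separated from the single-ring groups of compound 2 and compound 3, with a 1.1-fold higher number from compound 3 to compound 4 (0.04 log units; within the scatter) and a 1.2-fold lower number from compound 2 to compound 4 (0.09 log units; within the scatter) on record. The 2-chlorophenyl group of compound 1 remains the only one set apart, with a 3.0-fold lower number from compound 1 to compound 4 (0.48 log units; beyond the scatter) adding a third step of similar size. No data at hand explain this.

Open, as far as these compounds go, is whether pyridin-3-yl, cyclohexyl or naphthalen-2-yl at this place would give numbers in the same range. Also open, from the compounds shown here alone, is how a longer chain in the shared core would read.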